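The source may report more compounds than this note shows. Statements on the series, on what has been measured and on what is new or still open speak of the compounds shown alone.

Working notes on the series in a functional assay on the whole organism with Mus musculus as the target; on this read-out lower numbers stand for an effect already at smaller amounts and higher numbers for an effect only at larger amounts of compound. Among the measured compounds shown here, compound 1, `Cc1nnc(CNC(=O)CN)n1-c1ccc(Cl)cc1C(=O)c1ccccc1F`, has the lowest of the two numbers so far: in this assay compound 1 gives 0.16 mg/kg. The nearest is compound 2, `CN(C(=O)CNC(=O)CN)c1ccc(Cl)cc1C(=O)c1ccccc1Cl`, which in this assay gives 2.59 mg/kg, a higher number by a gap beyond the usual scatter. Compound 3, `Cc1nnc(CNC(=O)CN)n1-c1ccc(Cl)cc1C(=O)c1ccccc1Cl`, is not yet measured. It differs from compound 1 by chloro in place of fluoro on an aromatic carbon. For the measured compounds named here, no measured pair shows this change, so no step of comparable kind is known. A step from compound 1 to compound 3 of no change at the digits printed from compound 1 to compound 3 (within the scatter) is expected, that is, none beyond the scatter. For compound 3 the estimate is 0.16 mg/kg, within 0.06 mg/kg to 0.45 mg/kg.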

Compound 3, dose for half-maximal effect: 0.62 mg/kg
Beside the measured number, compound 3's estimate is 3.9-fold (0.59 log units) below it, and the stated range ends below it.
By their numbers in this assay, from the lowest: compound 1; then compound 3; then compound 2.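

Going from 2-fluorophenyl to 2-chlorophenyl, this assay shows a 3.9-fold higher number from compound 1 to compound 3 (0.59 log units; beyond the scatter) and so gives the first reading at this place: the number responds to which halogen is present, and fluoro gives the lower number of this pair. The step is modest, and it comes from one exchange on an otherwise unchanged structure. No measurement shown accounts for this step.

Open, on these data alone, is how hydrogen, bromo, methyl or methoxy at this place would compare with fluoro and chloro. Also open, as far as these compounds go, is whether the same exchange would give a step of similar size on the core of compound 2.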